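This account rests on a few compounds, and the source may have more. Where it says the series, first, only, none or still open, it means among the compounds named here.

Measured in a functional assay on KB cells (Homo sapiens) for antiproliferative activity, read by MTT assay, with a stated time of 72 h; on this read-out higher numbers stand for weaker inhibition and lower numbers for stronger inhibition:
Compound 1 `CCOC(=O)c1cc(-c2ccc(OC)c(OCc3ccccc3)c2)c(-c2cc(OC)c(OC)c(OC)c2)s1`: > 100000 nM (a limit)
Compound 2 `COc1ccc(-c2ccsc2-c2cc(OC)c(OC)c(OC)c2)cc1[N+](=O)[O-]`: 21000 nM

Among the compounds with values here, compound 2 holds the only numeric value so far, as the other result is a limit. Compound 3 `COc1ccc(-c2ccsc2-c2cc(OC)c(OC)c(OC)c2)cc1OCc1ccccc1` differs from compound 2 by benzyloxy in place of nitro on an aromatic carbon, ortho to a methoxy group. Compound 1 also carries benzyloxy, and its > 100000 nM is a limit. Within the data shown here, no measured step is available, so the expectation rests on that limit alone: weaker inhibition in this assay, by a moderate margin beyond the scatter. The expected change is a 2.4-fold higher number from compound 2 to compound 3 (0.38 log units; beyond the scatter). For compound 3 the estimated value is 50000 nM, with an expected range of 15000 nM to 100000 nM.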

Compound 3, half-maximal inhibitory concentration: > 100000 nM
Compound 3 gave a limit, no number; the forecaster's own chance of this, stated with the estimate: 35%; middle value at least 2.0-fold (0.30 log units) away from the limit.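

In this assay, within the data shown here, benzyloxy in place of nitro on this aromatic carbon, ortho to a methoxy group, gives an at least 4.7-fold higher number from compound 2 to compound 3 (0.67 log units; beyond the scatter), the first readable step. Compound 3 gives > 100000 nM, which is a limit and not a number. The full size of that step and the step between compound 1 and compound 3 cannot be read because the results reach the limit: the limit of > 100000 nM in this assay, at which 2 of the 3 values shown sit.

Still open, on these data alone, is where an amine or a hydroxyl on this carbon would fall relative to compound 2. Also open, as far as these compounds go, is whether any group here gives stronger inhibition than nitro.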